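Moving a bromine around the ring in an oxazole series

The source may hold more compounds than are shown below. What is called first, only, known or untested is meant among the compounds shown, and "the series" means these compounds.

Compound 1 `O=[N+]([O-])c1ccc(CN2CCC(n3cc(CC(OCc4cc(-c5ccc(Br)cc5)no4)c4ccc(Br)cc4)nn3)CC2)cc1` was tested in a functional assay on MDA-MB-468 cells (Homo sapiens) for cytotoxicity, with a stated time of 48 h (a lower number here means a stronger inhibitor, a higher number a weaker inhibitor), and gave 5000 nM, the second highest of the three numbers recorded. Compound 2 `O=[N+]([O-])c1ccc(CN2CCC(n3cc(CC(OCc4cc(-c5ccc(F)cc5)no4)c4ccc(Br)cc4)nn3)CC2)cc1` gave 4000 nM in this assay, and compound 3 `COc1ccc(-c2cc(COC(Cc3cn(C4CCN(Cc5ccc([N+](=O)[O-])cc5)CC4)nn3)c3ccc(Br)cc3)on2)cc1` gave 9000 nM. All three share one core and differ only in the group on the phenyl ring attached to the five-membered aromatic ring with one nitrogen and one oxygen. The steps among them were small: a 1.3-fold lower number from compound 1 to compound 2 (0.10 log units; within the scatter), a 1.8-fold higher number from compound 1 to compound 3 (0.26 log units; within the scatter) and a 2.3-fold higher number from compound 2 to compound 3 (0.35 log units; beyond the scatter). Compound 4 `O=[N+]([O-])c1ccc(CN2CCC(n3cc(CC(OCc4cc(-c5cccc(Br)c5)no4)c4ccc(Br)cc4)nn3)CC2)cc1` keeps every atom of compound 1 but moves the bromine: 3-bromophenyl in place of 4-bromophenyl on an aromatic carbon. For the measured compounds named here, no measured step moves a group around this ring; the three known steps only swap what sits in one place, and none reached beyond a modest size. On that basis the change from compound 1 to compound 4 is expected to stay within the scatter, with no clear direction, a step of no change at the digits printed from compound 1 to compound 4 (within the scatter). Compound 4 is therefore estimated at 5000 nM in this assay, with a range from 2000 nM to 12000 nM.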

Compound 4, half-maximal inhibitory concentration: > 25000 nM
Compound 4 was reported as a limit; the forecaster's own chance of this, stated with the estimate: 10%; middle value at least 5.0-fold (0.69 log units) away from the limit.
By their numbers in this assay, from the lowest: compounds 2, 1 and 3 (each within the scatter of the next, the first and the last beyond it). At a limit, above all of these: compound 4.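

In this assay compound 4 gives a limit of the assay rather than a number: the limit of > 25000 nM in this assay, at which 1 of the 4 values shown sits. Swapping the group on this phenyl ring had produced only small steps, yet moving the bromine while keeping every atom gives an at least 5.0-fold higher number from compound 1 to compound 4 (0.69 log units; beyond the scatter). The 3-bromophenyl compound also stands apart from the other two, with an at least 2.7-fold higher number from compound 3 to compound 4 (0.44 log units; beyond the scatter) and an at least 6.2-fold higher number from compound 2 to compound 4 (0.79 log units; beyond the scatter), so among these four compounds, where the bromine sits on the ring changes the number more than the swaps among 4-bromophenyl, 4-fluorophenyl and 4-methoxyphenyl did.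

From the compounds shown here alone, since compound 4 is a limit, the true size of these steps stays open. Also open, going by these compounds, is whether a fluorine or a methoxy group moved in the same way would behave like the bromine, and what an amine or a carboxylic acid in its place would do.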